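The source may hold more compounds than are shown below. What is called first, only, known or untested is meant among the compounds shown, and "the series" means these compounds.

Compound 1 `CCOC(=O)C1=C(C)NC(=S)NC1c1cn(C(=O)CNc2ccccc2[N+](=O)[O-])c2ccccc12`: in a physicochemical assay for lipophilicity (on this read-out lower numbers stand for lower lipophilicity and higher numbers for higher lipophilicity), compound 1 gives 2.88.
Compound 2 `CCOC(=O)C1=C(C)NC(=S)NC1c1cn(C(=O)CNc2cccc([N+](=O)[O-])c2)c2ccccc12`: in this assay compound 2 gives 2.88.

Compound 2 stands level with compound 1 at the digits shown; the step of no change at the digits printed from compound 1 to compound 2 (within the scatter) moved the nitro group from one position on the phenyl ring to another and left the read-out unchanged within the scatter. Compound 3 `CCOC(=O)C1=C(C)NC(=S)NC1c1cn(C(=O)CNc2ccc([N+](=O)[O-])cc2)c2ccccc12` has not yet been measured. It differs from compound 2 only in this way: 4-nitrophenyl in place of 3-nitrophenyl on an amine nitrogen. Among the compounds with values here, the one step that bears on it, no change at the digits printed from compound 1 to compound 2 (within the scatter), is again a shift of the nitro group around the same ring, and it produced no change beyond the scatter. For the step from compound 2 to compound 3 the expected change in this assay is therefore a number 0.02 log units higher from compound 2 to compound 3 (within the scatter), which is none beyond the scatter. Compound 3 is accordingly expected to give about 2.9, with a range from 2.6 to 3.2.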

Compound 3, partition coefficient: 2.88
Beside the measured number, compound 3's estimate is 0.02 log units above it; measured number inside the range.
By their numbers in this assay, from the lowest: compounds 1, 2 and 3 (each within the scatter of the next).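

With the 4-nitrophenyl group on the amine nitrogen, this assay shows no change at the digits printed from compound 2 to compound 3 (within the scatter) and also no change at the digits printed from compound 1 to compound 3 (within the scatter). The 2-nitrophenyl, 3-nitrophenyl and 4-nitrophenyl compounds can now be compared directly, and in these three compounds, the place of the nitro group on the phenyl ring makes no difference to this read-out beyond the scatter. No available evidence explains why the three compounds read alike.

All three compounds carry a nitro group, so these results do not show how this read-out would respond if a nitrile, a carboxylic acid or an amine took its place on the ring. Nor do they show what a plain phenyl group, without any nitro group, would give on the same amine nitrogen.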